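A few compounds are considered here, and "the series" means these few. Any claim that something is new, unique, unknown or untested is made for them only; others in the source may bear on it.

Compound 2 `COc1ccc(-c2cnc3nc(N)nc(N4CCN(c5ccccc5)CC4)c3n2)cc1OC` gives 400 nM in a functional assay on cells (T-cell, Homo sapiens) for inhibition (on this read-out higher numbers stand for weaker inhibition and lower numbers for stronger inhibition), the highest of the two numbers recorded so far, while compound 1 `COc1ccc(-c2cnc3nc(N)nc(N4CCN(C(=O)NCc5ccccc5)CC4)c3n2)cc1OC` gives 18 nM. The gap between them is the step of a 22-fold higher number from compound 1 to compound 2 (1.35 log units; beyond the scatter). Compound 3 `COc1ccc(-c2cnc3nc(N)nc(N4CCN(C(=O)Nc5ccc(F)cc5)CC4)c3n2)cc1OC` differs from compound 2 in one place: (4-fluorophenyl)carbamoyl in place of phenyl on an amine nitrogen in a ring. Because the step of a 22-fold higher number from compound 1 to compound 2 (1.35 log units; beyond the scatter) followed the loss of a carbamoyl from this ring nitrogen, bringing a carbamoyl back is expected to undo much of that step, as a step of a 13-fold lower number from compound 2 to compound 3 (1.12 log units; beyond the scatter) towards a lower number. Compound 3 is therefore estimated at 30 nM, within a range from 8 nM to 120 nM.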

Compound 3, half-maximal inhibitory concentration: 7 nM
Beside the measured number, compound 3's estimate is 4.3-fold (0.63 log units) above it; the measured number lies below the stated range.
By their numbers in this assay, from the lowest: compound 3; then compound 1; then compound 2.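

With the step of a 57-fold lower number from compound 2 to compound 3 (1.76 log units; beyond the scatter) in this assay, a carbamoyl on the amine nitrogen in the ring again stands far from phenyl alone, and this holds with 4-fluorophenyl as well as with the benzyl of compound 1. On the amide-type nitrogen, 4-fluorophenyl in place of benzyl gives the modest step of a 2.6-fold lower number from compound 1 to compound 3 (0.41 log units; beyond the scatter) and so keeps the low number.

The compounds shown leave open how much of that step belongs to the fluorine and how much to the loss of the benzyl methylene, and whether a plain phenyl or a 4-chlorophenyl on this carbamoyl would match it. No evidence on the cause of these differences is at hand.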